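Swapping One Fluorinated Group on Compound 2

A few compounds are considered here, and "the series" means these few. Any claim that something is new, unique, unknown or untested is made for them only; others in the source may bear on it.

In a functional assay on LNCaP cells (Homo sapiens) for antiproliferative activity, read by propidium iodide staining, with a stated time of 96 h (on this read-out lower numbers stand for stronger inhibition and higher numbers for weaker inhibition), compound 1 `CC(O)(CSc1ccc(OC(F)(F)F)cc1)C(=O)Nc1cccc(S(F)(F)(F)(F)F)c1` gives 10300 nM and compound 2 `CC(O)(CS(=O)(=O)c1cccc(S(F)(F)(F)(F)F)c1)C(=O)Nc1cccc(S(F)(F)(F)(F)F)c1` gives 11700 nM as its value. These two numbers lie within the usual scatter of each other, so compound 2 stands level with compound 1, even though their structures differ in more than one place.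

Compound 3 `CC(O)(CS(=O)(=O)c1cccc(C(F)(F)F)c1)C(=O)Nc1cccc(S(F)(F)(F)(F)F)c1` has not yet been measured. It differs from compound 2 by a single swap (a group of 4 heavy atoms (1 carbon, 3 fluorine; no ring) in place of a group of 6 heavy atoms (5 fluorine, 1 sulfur; no ring), on an aromatic carbon): trifluoromethyl enters on an aromatic carbon, meta to a large group, in place of a group of 5 fluorine atoms and 1 sulfur atom.

Within the data shown here, no two measured compounds differ in just one place, so no measured step shows what this swap does. Among the measured compounds shown here, the only guide is the closeness of compound 1 (10300 nM) and compound 2 (11700 nM), and two compounds are thin evidence. No change beyond the scatter is therefore expected in this assay, in either direction. The estimated step of a 1.1-fold lower number from compound 2 to compound 3 (0.03 log units; within the scatter) is accordingly small. For compound 3 the estimated value is 11000 nM with 5000 nM to 24000 nM as the expected range.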

Compound 3, half-maximal inhibitory concentration: 21800 nM
Estimate against measurement, compound 3: 2.0-fold (0.30 log units) below; low and high end bracket the measured number.
By their numbers in this assay, from the lowest: compounds 1, 2 and 3 (each within the scatter of the next, the first and the last beyond it).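

Among these compounds, this is the first pair that differs in one place only, so it isolates the swap at this aromatic carbon: in this assay, trifluoromethyl replacing the group of 5 fluorine atoms and 1 sulfur atom gives a 1.9-fold higher number from compound 2 to compound 3 (0.27 log units; within the scatter) while the rest of the molecule stays the same. The step lies within the scatter, so this read-out does not separate the two groups at this position, and the larger group shows no measurable advantage over the smaller one in this single pair. Nothing measured here explains the size of this step, and a single pair cannot establish a trend for this position.

The compounds shown leave open how this aromatic carbon responds to groups of a different kind, such as a nitrile, a methyl group, a chlorine atom or a plain hydrogen atom, any of which would test whether a fluorinated group is needed there at all. They also leave open whether the same swap, made at the matching group on the other side of the amide, would give a similarly small step.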